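This account rests on a few compounds, and the source may have more. Where it says the series, first, only, none or still open, it means among the compounds named here.

Measured so far:
Compound 1, `COc1ccc(/C=C/C(=O)c2ccc(OC)c(OC)c2)cc1O` — 82.1%
Compound 2, `COc1ccc(C(=O)/C=C/c2cc(OC)ccc2OC)c(O)c1` — 93.3%
Compound 3, `COc1ccc(CCCc2cccc(OC)c2OC)c(O)c1` — 99%

Three compounds were tested in an ADME assay on RAW264.7 cells (Mus musculus) for cytotoxicity, read by MTT assay, with a stated time of 24 h, tested at 2.5 ug/mL; on this read-out higher numbers stand for a weaker effect at the one concentration tested and lower numbers for a stronger effect. Compound 1 gives 82.1%, the lowest of the three numbers, so it shows the strongest effect on the cells at the single concentration used. The nearest number belongs to compound 2 with 93.3%, which lies higher than compound 1 by a gap beyond the usual scatter. The furthest belongs to compound 3 with 99%, higher again and also beyond the scatter. Compound 2 and compound 3 are not connected by a single-point step, so only their two values can be compared as they stand.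

The next compound, compound 4, `COc1ccc(/C=C/C(=O)c2ccc(OC)c(OC)c2)cc1`, is compound 1 with one change: hydrogen in place of hydroxy on an aromatic carbon. Within the data shown here, no pair among the measured compounds differs in a single place, so there is no measured step to lean on. A change of one heavy atom on the aromatic ring is expected to move the number only a little, if at all, and if anything toward a weaker effect. The step of a number 5.9 percentage points higher from compound 1 to compound 4 (within the scatter) is estimated to stay within the scatter. For compound 4 the expected value is 88%, within 72% to 100%.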

Compound 4, a percentage reported as activity, at one concentration (the size of the read-out at that concentration, not a potency): 93.1%
Beside the measured number, compound 4's estimate is 5.1 percentage points below it, within the range that was stated.
By their numbers in this assay, from the lowest: compound 1; then compounds 4, 2 and 3 (each within the scatter of the next).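

Among these compounds, this is the first pair here that differs in only one place, so a single change can be read on its own: in this assay, hydrogen in place of hydroxy on the aromatic carbon ortho to a methoxy group gives a number 11 percentage points higher from compound 1 to compound 4 (beyond the scatter) on the shared core. Since a higher number stands for a weaker effect on the cells, compound 1, which carries the hydroxy group, has the stronger effect of the pair, and this one small change is enough to carry the number beyond the usual scatter. Nothing available explains why the number moves, so the step stands as an observation only.

The compounds shown carry only hydroxy or hydrogen at this place, so it stays open whether an amine, a fluorine atom or a carboxylic acid there would behave like compound 1 or like compound 4. Also open, as far as these compounds go, is whether the same change would give a similar step in compound 2, which also carries a hydroxy group, and how the pair would compare at other concentrations.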